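Swapping the benzyl group on the sulfur: toward compound 3

The compounds below may be only part of what the source reports. "The series", "measured", "known", "first", "only" and "open" are said of these compounds alone.

In a functional assay on HeLa cells (Homo sapiens) for antiproliferative activity, read by MTT assay, with a stated time of 24 h (on this read-out lower numbers stand for stronger inhibition and higher numbers for weaker inhibition), compound 1 (`Cc1ccc(CSc2nnc(-c3ccc4c(c3)OCCO4)n2-c2ccccc2)cc1`) gives 49700 nM and compound 2 (`Fc1cccc(F)c1CSc1nnc(-c2ccc3c(c2)OCCO3)n1-c1ccccc1`) gives 35200 nM on the same shared core. Going by the values given here, these are the only two numbers available. Among the compounds with values here, compound 2 therefore has compound 1 as its sole neighbour, and the two sit within the scatter of repeated measurements, so neither can be ranked above the other.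

The next structure is compound 3 (`Brc1ccc(CSc2nnc(-c3ccc4c(c3)OCCO4)n2-c2ccccc2)cc1`). It keeps the core and alters one group (4-bromophenyl in place of 2,6-difluorophenyl on a saturated chain carbon bound to a sulfur) with 4-bromophenyl in place of 2,6-difluorophenyl on a saturated chain carbon bound to a sulfur.

Within the data shown here, one measured step bears on this place, and it is a 1.4-fold lower number from compound 1 to compound 2 (0.15 log units; within the scatter) with the group on that same chain carbon exchanged. Among the measured compounds shown here, that single step is a thin guide, and no measured compound yet carries the 4-bromophenyl group. With only this to go on, no change beyond the scatter is expected in this assay and no direction can be favoured. The expected step is a 1.1-fold higher number from compound 2 to compound 3 (0.06 log units; within the scatter) and it is small. For compound 3 the estimated value is 40000 nM with an expected range from 18000 nM to 90000 nM in this measurement.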

Compound 3, half-maximal inhibitory concentration: 54600 nM
Estimate against measurement, compound 3: 1.4-fold (0.14 log units) below, within the range that was stated.
By their numbers in this assay, from the lowest: compounds 2, 1 and 3 (each within the scatter of the next).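

In this assay, a third group now sits on the saturated chain carbon bound to a sulfur: 4-bromophenyl in place of 2,6-difluorophenyl gives a 1.6-fold higher number from compound 2 to compound 3 (0.19 log units; within the scatter) as its step, and bromo in place of methyl on an aromatic carbon gives a 1.1-fold higher number from compound 1 to compound 3 (0.04 log units; within the scatter) as its step. Going by these compounds alone, the earlier pair offered only two groups at this position, whereas all three pairs among 4-methylphenyl, 2,6-difluorophenyl and 4-bromophenyl now lie within the scatter, so these three groups cannot be ranked, and neither can bromo and methyl on that aromatic carbon. No measurement shown here explains this outcome.

The compounds shown leave open whether a phenyl ring carrying an amine or a carboxylic acid, or a longer chain on the sulfur, would give a step beyond the scatter. They also leave open whether the three groups would stay indistinguishable in cells other than the HeLa cells used here.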